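The source may report more compounds than this note shows. Statements on the series, on what has been measured and on what is new or still open speak of the compounds shown alone.

Measured so far:
compound 1 `COc1ccc(CN2CCC(C(=O)Nc3cc(Cl)c(N)cc3OC)CC2)cc1` gives 0.9 mg/kg in a functional assay on the whole organism for antagonist activity, with Mus musculus as the target; a lower number here means that less compound is needed, a higher number that more compound is needed for the effect
compound 2 `CCN1CCC(C(=O)Nc2cc(Cl)c(N)cc2OC)CC1` gives > 10 mg/kg in this assay

The value of compound 2 is a limit of this assay, not a number. Compound 1 therefore holds the only number shown; the other value sits at the limit of > 10 mg/kg in this assay, at which 1 of the 2 values shown sits. The step of an at least 11-fold higher number from compound 1 to compound 2 (1.04 log units; beyond the scatter) is large. Compound 3 `COc1cc(N)c(Cl)cc1NC(=O)C1CCN(Cc2ccccc2)CC1` differs from compound 1 by hydrogen in place of methoxy on an aromatic carbon. For the measured compounds named here, this is a smaller change than the one from compound 1 to compound 2, and no measured step tests the methoxy alone, so a step within the scatter is expected, with a 1.7-fold higher number from compound 1 to compound 3 (0.22 log units; within the scatter) as the estimate. Compound 3 is expected at 1.5 mg/kg, between 0.5 mg/kg and 5 mg/kg.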

Compound 3, dose for half-maximal effect: 0.5 mg/kg
Compound 3: middle estimate off by 3.0-fold (0.48 log units), on the high side; measured number inside the range.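

In this assay, the 4-methoxybenzyl group can give way to benzyl with a 1.8-fold lower number from compound 1 to compound 3 (0.26 log units; within the scatter), so the methoxy is not needed for the effect at this aromatic carbon. The large gain over methyl also holds without the methoxy, with an at least 20-fold lower number from compound 2 to compound 3 (1.30 log units; beyond the scatter), which the earlier pair could not show. Compound 2 stands at a limit of the assay, not at a number: the limit of > 10 mg/kg in this assay, at which 1 of the 3 values shown sits.

On these data alone, whether a fluorine, a hydroxyl or an amine on this aromatic carbon would keep the number within the scatter stays open. So does the effect of a longer chain between the phenyl and the ring nitrogen.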